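The source may hold more compounds than are shown below. What is called first, only, known or untested is meant among the compounds shown, and "the series" means these compounds.

Compound 1 `CCn1c(-c2cnc(C)nc2)nc2c(N[C@H]3CCN(C(=O)[C@H]4C[C@@H](OC)C4)C3)ncnc21`: 1.5 L/kg
Compound 2 `CCn1c(-c2cnc(C)nc2)nc2c(N[C@H]3CCN(C(=O)C4CC(F)(F)C4)C3)ncnc21`: 0.9 L/kg
Compound 3 `CCn1c(-c2cnc(C)nc2)nc2c(O[C@H]3CCN(C(=O)[C@H]4C[C@@H](OC)C4)C3)ncnc21`: 0.5 L/kg

These three compounds have been measured in an ADME assay (Rattus norvegicus, strain Wistar Han) for pharmacokinetics; on this read-out lower numbers stand for narrower distribution and higher numbers for wider distribution into tissues. Compound 1 gives 1.5 L/kg, compound 2 gives 0.9 L/kg and compound 3 gives 0.5 L/kg.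

Compound 1 and compound 2 share one core and differ in a single place: 3,3-difluorocyclobutyl in place of 3-methoxycyclobutyl on a carbonyl carbon. That change gave a 1.7-fold lower number from compound 1 to compound 2 (0.22 log units; within the scatter). Compound 3 carries a different core from compound 1; the difference between the two cores is not broken down here. In this assay the gap between compound 3 and compound 1 lies beyond the scatter, while the gap between compound 3 and compound 2 lies within it.

Compound 4 `CCn1c(-c2cnc(C)nc2)nc2c(O[C@H]3CCN(C(=O)C4CC(F)(F)C4)C3)ncnc21` has not yet been measured in this assay. It stands to compound 3 exactly as compound 2 stands to compound 1: 3,3-difluorocyclobutyl in place of 3-methoxycyclobutyl on a carbonyl carbon, at the same place. The change is therefore the same one already seen once. Its effect on compound 4 is estimated as a 1.4-fold lower number from compound 3 to compound 4 (0.15 log units; within the scatter) because the earlier instance gave a 1.7-fold lower number from compound 1 to compound 2 (0.22 log units; within the scatter). Compound 4 is accordingly expected to give 0.35 L/kg, with a likely range from 0.2 L/kg to 0.7 L/kg.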

Compound 4, volume of distribution: 0.5 L/kg
Estimate against measurement, compound 4: 1.4-fold (0.15 log units) below; measured number inside the range.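

In this assay, 3,3-difluorocyclobutyl in place of 3-methoxycyclobutyl on the second core gave no change at the digits printed from compound 3 to compound 4 (within the scatter). Set side by side, the two results agree as closely as repeated measurements can show, which means that in these four compounds the change carries from one core to the other without a detectable difference: the same change on two cores in this assay, a 1.7-fold lower number (0.22 log units; within the scatter) from compound 1 to compound 2 and no change at the digits printed (within the scatter) from compound 3 to compound 4, 1.7-fold (0.22 log units) apart, within the scatter of two such steps. This does not show that the change has no effect, or that it acts identically on every core: two steps within the scatter cannot separate a small effect from none, and two cores are too few to support a general rule.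

The compounds shown leave open how a plain unsubstituted cyclobutyl, a longer carbon chain or an amine on the same carbonyl carbon would read in this assay. They also leave open whether the same change would again make so little difference on a third core.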